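A few compounds are considered here, and "the series" means these few. Any claim that something is new, unique, unknown or untested is made for them only; others in the source may bear on it.

In an ADME assay on microsomes from liver (Rattus norvegicus, strain Han Wistar) for metabolic stability, read by LC-MS, with a stated time of 60 min, tested at 1 uM, in the presence of a further agent that is not named here (on this read-out higher numbers stand for fast clearance and lower numbers for slow clearance), compound 1 `CC[C@@H](Nc1c(C#N)c(-c2ccc(-c3cccc(Cl)c3F)cc2)nc2cnccc12)C(N)=O` gives 2.33 mL/min/kg and compound 2 `CCOc1ccccc1-c1ccc(-c2nc3cnccc3c(N[C@H](CC)C(=O)O)c2C#N)cc1` gives 8.33 mL/min/kg, the higher of the two numbers, with a gap beyond the scatter. Compound 3 `CC[C@@H](Nc1c(C#N)c(-c2ccc(-c3cccc(C)c3F)cc2)nc2cnccc12)C(=O)O` differs from compound 2 at one place, with 2-fluoro-3-methylphenyl in place of 2-ethoxyphenyl on an aromatic carbon. Among the measured compounds shown here, no measured pair of compounds isolates this kind of exchange, so no shift beyond the scatter is expected in this assay. The expected change is a 1.4-fold lower number from compound 2 to compound 3 (0.14 log units; within the scatter), a small drop within the scatter. For compound 3 the estimated clearance is 6 mL/min/kg, with an expected range from 2.5 mL/min/kg to 14 mL/min/kg.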

Compound 3, clearance: 46.7 mL/min/kg
Compound 3: middle estimate off by 7.8-fold (0.89 log units), on the low side, and the stated range ends below it.
By their numbers in this assay, from the lowest: compound 1; then compound 2; then compound 3.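

In this assay, the swap of 2-ethoxyphenyl for 2-fluoro-3-methylphenyl gives a 5.6-fold higher number from compound 2 to compound 3 (0.75 log units; beyond the scatter), on an aromatic carbon para to a large group. This position therefore does not tolerate every aryl group alike, and a change of one ring substituent pattern here is enough to move clearance beyond the scatter. No available evidence accounts for the rise.

Open, going by these compounds, is what a chlorine in place of the methyl would do while the carboxylic acid stays. Also open, on these data alone, is whether a primary amide in place of that acid would change the clearance of compound 3.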